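Acetyl for dimethylamino on the aryl of compound 1

This account rests on a few compounds, and the source may have more. Where it says the series, first, only, none or still open, it means among the compounds named here.

compound 1 `COc1cc(C)cc(-c2c(-c3ccnc(-c4ccc(N(C)C)cc4)c3)cnn2CC#N)c1`: -36%
compound 2 `Cc1cc(O)cc(-c2nn(CC#N)cc2-c2ccnc(-c3ccc(Oc4ccccc4)cc3)c2)c1`: 85%
compound 3 `Cc1cc(O)cc(-c2nn(CC#N)cc2-c2ccnc(-c3ccc(N(C)C)cc3)c2)c1`: 66%

In a functional assay on KM12 cells (Homo sapiens) for cytotoxicity, read by sulforhodamine B assay, with a stated time of 48 h, tested at 100 nM (a higher number here means a weaker effect of the compound at the concentration tested, a lower number a stronger effect), compound 1 holds the lowest number of the three, well apart from compound 3 and further still from compound 2. Among the compounds with values here, the one measured step in this set, a number 19 percentage points lower from compound 2 to compound 3 (beyond the scatter), concerns dimethylamino against phenoxy and does not cover the change now in view. Compound 4 `COc1cc(C)cc(-c2c(-c3ccnc(-c4ccc(C(C)=O)cc4)c3)cnn2CC#N)c1` differs from compound 1 in one place: acetyl in place of dimethylamino on an aromatic carbon. Within the data shown here, no measured pair carries acetyl, so no comparison fixes the direction of this step; the gap between compound 1 and compound 3, both carrying dimethylamino, shows only how far the rest of the molecule can move the number. Compound 4 is therefore expected at 20%, with a range from -30% to 80%, which would mean an expected upward step a number 56 percentage points higher from compound 1 to compound 4 (beyond the scatter) beyond the scatter.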

Compound 4, a percentage reported as activity, at one concentration (the size of the read-out at that concentration, not a potency): 85%
Estimate against measurement, compound 4: 65 percentage points below, and the stated range ends below it.
By their numbers in this assay, from the lowest: compound 1; then compound 3; then compounds 2 and 4 (each within the scatter of the next).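

In this assay, within the data shown here, 4-(dimethylamino)phenyl to 4-acetylphenyl on the core of compound 1 gives a number 121 percentage points higher from compound 1 to compound 4 (beyond the scatter), the first measured step at this position on that core. Dimethylamino and acetyl have the same count of heavy atoms and neither has a ring, so a swap that leaves these counts unchanged is enough for a large step here. Nothing available gives a cause for this step.

Open, from the compounds shown here alone, is whether an amine such as pyrrolidine or morpholine, or a carboxylic acid, in this place stays near compound 1. Also open, going by these compounds, is what acetyl does on the hydroxyl-bearing core of compound 3.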